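Compound 4: a trifluoromethoxy swap under a cytotoxicity limit

The source may report more compounds than this note shows. Statements on the series, on what has been measured and on what is new or still open speak of the compounds shown alone.

Values in an ADME assay on Vero cells (Chlorocebus sabaeus) for cytotoxicity (on this read-out lower numbers stand for higher toxicity in this test and higher numbers for lower toxicity in this test), so far:
compound 1 `O=c1nc(N2CCN(CC3CCCCC3)CC2)sc2c([N+](=O)[O-])cc(C(F)(F)F)cc12` gives > 64 ug/mL as a limit
compound 2 `CC(c1cc(F)cc(F)c1)N1CC2(CCN(c3nc(=O)c4cc(C(F)(F)F)cc([N+](=O)[O-])c4s3)CC2)C1` gives > 64 ug/mL as a limit
compound 3 `CC(c1cc(F)c(F)c(F)c1)N1CC2(CCN(c3nc(=O)c4cc(C(F)(F)F)cc([N+](=O)[O-])c4s3)CC2)C1` gives > 64 ug/mL as a limit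

Compound 3 stands at > 64 ug/mL in this assay, which is a limit and not a number. Compound 1 and compound 2 also have only limits, so the three compounds cannot be ranked.

Compound 4 `CC(c1ccc(OC(F)(F)F)cc1)N1CC2(CCN(c3nc(=O)c4cc(C(F)(F)F)cc([N+](=O)[O-])c4s3)CC2)C1` has yet to be measured. It carries 4-(trifluoromethoxy)phenyl in place of 3,4,5-trifluorophenyl on a saturated chain carbon bound to an amine nitrogen in a ring and a saturated chain carbon, a difference counted as 4-(trifluoromethoxy)phenyl in place of 3,4,5-trifluorophenyl on a saturated chain carbon bound to an amine nitrogen in a ring and a saturated chain carbon and left to be tested.

Among the measured compounds shown here, the one measured step is a step that the two limits leave unreadable from compound 2 to compound 3, with fluoro in place of hydrogen on an aromatic carbon, and it gives no size to carry over. The expectation therefore rests on compound 3, whose limit is > 64 ug/mL, and on the limit of > 64 ug/mL in this assay, at which 3 of the 3 values shown sit, for the series as a whole.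

No step beyond the scatter is expected, and the estimated step is a number no higher from compound 3 to compound 4 (the limit leaves the size open) in either direction. For compound 4 the estimated value is 64 ug/mL, with an expected range from 32 ug/mL to 128 ug/mL in this assay and a reading at the limit as the likeliest outcome.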

Compound 4, half-maximal cytotoxic concentration: > 64 ug/mL
Compound 4 gave a limit, no number (the forecaster's own chance of this, stated with the estimate: 85%); the middle value lies on the limit itself.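

In this assay compound 4 gives > 64 ug/mL, which is a limit and not a number. The steps from compound 2 and from compound 3 to compound 4 cannot be read. The compounds shown leave open whether 4-(trifluoromethoxy)phenyl in place of 3,4,5-trifluorophenyl changes cytotoxicity at all, with the whole series resting on a single reading: the limit of > 64 ug/mL in this assay, at which 4 of the 4 values shown sit.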